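Methyl Groups in Two Places on a Shared Core

The source may report more compounds than this note shows. Statements on the series, on what has been measured and on what is new or still open speak of the compounds shown alone.

Of the compounds shown here, three of a common core have been tested in a functional assay on HCT-116 cells (Homo sapiens) for cytotoxicity, read by MTT assay, with a stated time of 48 h; a lower number here means a stronger inhibitor, a higher number a weaker inhibitor. Compound 1 `Cc1ccc2nc(Cl)c(/C=N/n3cc(-c4ccccc4)nc3N)cc2c1` gives 7120 nM in this assay. Compound 2 `Cc1ccc(-c2cn(/N=C/c3cc4cc(C)ccc4nc3Cl)c(N)n2)cc1` carries one more group than compound 1, and in this assay compound 2 gives 39600 nM. The difference between them, (methyl in place of hydrogen on an aromatic carbon), made a step of a 5.6-fold higher number from compound 1 to compound 2 (0.75 log units; beyond the scatter). Compound 3 `Nc1nc(-c2cccc3ccccc23)cn1/N=C/c1cc2ccccc2nc1Cl` gives 6340 nM in this assay; the difference between the cores of compound 1 and compound 3 is not broken down here, and their two values lie within the usual scatter of each other.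

Compound 4 `Cc1ccc2nc(Cl)c(/C=N/n3cc(-c4cccc5ccccc45)nc3N)cc2c1` has not yet been measured in this assay. It differs from compound 3 by methyl in place of hydrogen on an aromatic carbon. Within the data shown here, this is the same kind of change as the one from compound 1 to compound 2, but not the same: there the methyl sat on a six-membered aromatic ring of carbon only, para to a large group, whereas here it sits on a six-membered aromatic ring of carbon only that is part of a fused system of two rings, meta to a fused ring and para to a fused ring. Among the measured compounds shown here, only one earlier step of this kind is known, and it was made in a different place, so it gives a direction rather than a firm size. Compound 4 is expected to lie at a step of a 1.6-fold higher number from compound 3 to compound 4 (0.20 log units; within the scatter) in this assay, a smaller weakening than before because the earlier step of a 5.6-fold higher number from compound 1 to compound 2 (0.75 log units; beyond the scatter) stood at a different place. Compound 4 is therefore estimated at 10000 nM, most likely between 4000 nM and 25000 nM.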

Compound 4, half-maximal inhibitory concentration: 5840 nM
Beside the measured number, compound 4's estimate is 1.7-fold (0.23 log units) above it, within the range that was stated.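

In this assay, the methyl change does not carry over in size from one core to the other, and the gap between the two steps is larger than repeat measurements would explain: the same change on two cores in this assay, a 5.6-fold higher number (0.75 log units; beyond the scatter) from compound 1 to compound 2 and a 1.1-fold lower number (0.04 log units; within the scatter) from compound 3 to compound 4, 6.0-fold (0.78 log units) apart, beyond the scatter of two such steps The new step, taken alone, is a 1.1-fold lower number from compound 3 to compound 4 (0.04 log units; within the scatter), so a large penalty for a methyl on one core cannot be assumed on another in this series. The two changes of the aromatic group fit this picture, with a 6.8-fold lower number from compound 2 to compound 4 (0.83 log units; beyond the scatter) for naphthalen-1-yl in place of 4-methylphenyl and a 1.2-fold lower number from compound 1 to compound 4 (0.09 log units; within the scatter) for naphthalen-1-yl in place of phenyl, but they do not show whether the core or the place of the methyl sets the outcome, since the methyl stands on a different ring in each of the two methyl steps.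

The compounds shown leave open what a methyl on the fused system of two rings does when the other aromatic group is phenyl, which would compare the two places more directly. Among these compounds, they also leave open whether other groups at either place, such as ethyl, methoxy or an amine, would behave like the methyl in the step to compound 2 or like the one in the step to compound 4.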